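The compounds below may be only part of what the source reports. "The series", "measured", "known", "first", "only" and "open" are said of these compounds alone.

Series values in a functional assay on RAW264.7 cells (Mus musculus) for inhibition, read by fluorescence, with stated times of 1 h, 24 h and 30 min; a lower number here means a stronger inhibitor, a higher number a weaker inhibitor:

- Compound 1 `O=C(/C=C/c1cccc(F)c1)c1ccccc1`: > 10000 nM, a limit of the assay.
- Compound 2 `O=C(/C=C/c1cccc(F)c1)c1cccc(O)c1`: > 10000 nM, a limit of the assay.
- Compound 3 `O=C(/C=C/c1cccc(C(F)(F)F)c1)c1ccccc1O`: "not determined" (no result reported).

Compound 2 has no number to its name, and its standing is the limit of > 10000 nM in this assay, at which 2 of the 3 values shown sit. Among the measured compounds shown here, the only other reading is the limit of compound 1, and compound 3 adds nothing.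

The step under consideration leads to compound 4 `O=C(/C=C/c1cccc(OC(F)(F)F)c1)c1cccc(O)c1`, which keeps the rest of compound 2 and carries trifluoromethoxy in place of fluoro on an aromatic carbon, meta to a large group: trifluoromethoxy in place of fluoro on an aromatic carbon.

For the measured compounds named here, the one measured step is a step that the two limits leave unreadable from compound 1 to compound 2. It is a change of hydroxy in place of hydrogen on an aromatic carbon, so it is a different change from this one, and its size cannot be read. Going by the values given here, no measured step involves fluoro or trifluoromethoxy, so neither a size nor a direction can be carried over to this assay.

The expectation is therefore weak: compound 4 most likely stays in the same region as compound 2, and the assay may again report only a limit. A modest gain cannot be excluded. The estimated change is a step that the limit leaves unreadable from compound 2 to compound 4. For compound 4 the expected value is 12000 nM, with an estimated range from 4000 nM to 40000 nM.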

Compound 4, half-maximal inhibitory concentration: > 10000 nM
Compound 4 gave a limit, no number; the forecaster's own chance of this, stated with the estimate: 65%; the middle value does not contradict the limit.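

In this assay compound 4 gives > 10000 nM as a limit of the assay. Compound 2 also rests on a limit, so no size can be read for the change between compound 2 and compound 4, and the standing of compound 2 is unchanged: the limit of > 10000 nM in this assay, at which 3 of the 4 values shown sit.

The compounds shown leave open whether any change on the shared core gives a readable value in this assay at all.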